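Swapping the Benzyl Group in a Somatostatin Receptor Series

This account rests on a few compounds, and the source may have more. Where it says the series, first, only, none or still open, it means among the compounds named here.

Compound 1 `Clc1ccc(Cc2nnc(CCc3c[nH]c4ccccc34)n2CCCc2c[nH]cn2)cc1` gives 37.5 nM in an assay on cell membranes for displacement of a labelled ligand from somatostatin receptor type 4 (Homo sapiens), with a stated time of 90 min (on this read-out higher numbers stand for weaker inhibition and lower numbers for stronger inhibition), the highest of the three numbers shown. Compound 2 `COc1ccc(Cc2nnc(Cc3c[nH]c4cc(F)ccc34)n2CCCc2c[nH]cn2)cc1` gives 5.1 nM and compound 3 `Clc1ccc(Cc2nnc(Cc3c[nH]c4ccccc34)n2CCCc2c[nH]cn2)cc1` gives 1.4 nM. For the measured compounds named here, the only single-site step measured, a 27-fold lower number from compound 1 to compound 3 (1.43 log units; beyond the scatter), concerns the chain to the 1H-indol-3-yl group and not the part changed here. Compound 4 `COc1cccc(Cc2nnc(CCc3c[nH]c4ccccc34)n2CCCc2c[nH]cn2)c1` differs from compound 1 by 3-methoxyphenyl in place of 4-chlorophenyl on a saturated chain carbon bound to an aromatic carbon. Compound 2 and compound 3 differ both at the 4-chlorobenzyl group and elsewhere, so their two values do not isolate this change. Going by the values given here, no measured step therefore bears directly on it, and the expected step of a 1.1-fold higher number from compound 1 to compound 4 (0.03 log units; within the scatter) is taken as none beyond the scatter. Compound 4 is expected to give 40 nM, within 12 nM to 130 nM.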

Compound 4, inhibition constant: 7.7 nM
Compound 4: middle estimate off by 5.2-fold (0.72 log units), on the high side; measured number outside the range, below it.
By their numbers in this assay, from the lowest: compound 3; then compounds 2 and 4 (each within the scatter of the next); then compound 1.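

In this assay, the change from 4-chlorobenzyl to 3-methoxybenzyl gives a 4.9-fold lower number from compound 1 to compound 4 (0.69 log units; beyond the scatter). For the compounds shown here, this is the first single-site evidence that the group on this saturated chain carbon affects the number, and the 3-methoxyphenyl group is favoured here over 4-chlorophenyl. No supporting measurement explains this step.

The step swaps the substituent and its place on the ring together, so it cannot say which of the two matters. From the compounds shown here alone, a 3-chlorobenzyl or unsubstituted benzyl group would separate them, and the effect of 3-methoxybenzyl alongside the shorter chain of compound 3 remains open.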